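Removing a methyl from compound 1

The compounds below may be only part of what the source reports. "The series", "measured", "known", "first", "only" and "open" are said of these compounds alone.

Measured in a physicochemical assay for solubility, read by HPLC, in phosphate buffer, measured as kinetic solubility, at pH 7.4 (on this read-out lower numbers stand for lower solubility and higher numbers for higher solubility), so far
compound 1 `CCOC(=O)c1cc(-c2ccc(F)cc2)n(-c2ccc(S(N)(=O)=O)cc2)c1C` gives 12600 nM
compound 2 `CCOC(=O)c1cc(-c2cccc(Cl)c2)n(-c2ccc(S(N)(=O)=O)cc2)c1C` gives 9200 nM
compound 3 `CCOC(=O)c1cc(-c2ccc(C)cc2)n(-c2ccc(S(N)(=O)=O)cc2)c1C` gives 1300 nM

Compound 1 shares the top of this small range: the nearest step is a 1.4-fold lower number from compound 1 to compound 2 (0.14 log units; within the scatter), and the furthest is a 9.7-fold lower number from compound 1 to compound 3 (0.99 log units; beyond the scatter). Compound 4 `CCOC(=O)c1cc(-c2ccc(F)cc2)n(-c2ccc(S(N)(=O)=O)cc2)c1` differs from it by hydrogen in place of methyl on an aromatic carbon, next to the ring nitrogen. Among the compounds with values here, no measured step makes this change at this place. The closest guides are modest steps at another place, which both end on a methyl: a 9.7-fold lower number from compound 1 to compound 3 (0.99 log units; beyond the scatter) and a 7.1-fold lower number from compound 2 to compound 3 (0.85 log units; beyond the scatter). In this assay, the expected outcome is therefore no step beyond the scatter, with wide uncertainty: a 1.3-fold higher number from compound 1 to compound 4 (0.10 log units; within the scatter). For compound 4 the estimated value is 16000 nM, with an expected range from 4500 nM to 50000 nM.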

Compound 4, solubility: 36400 nM
Beside the measured number, compound 4's estimate is 2.3-fold (0.36 log units) below it; the measured number falls inside the stated range.
By their numbers in this assay, from the lowest: compound 3; then compounds 2 and 1 (each within the scatter of the next); then compound 4.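

In this assay, within the data shown here, hydrogen in place of methyl on the aromatic carbon next to the ring nitrogen gives a 2.9-fold higher number from compound 1 to compound 4 (0.46 log units; beyond the scatter), the first reading at this position, since the earlier steps all lay at another place. The read-out therefore responds at this position to a change as small as the loss of a methyl, with a modest step beyond the scatter. Nothing available explains this step.

On these data alone, it remains open whether the step carries over to the 3-chlorophenyl group of compound 2 or the 4-methylphenyl group of compound 3. As far as these compounds go, it is also open what an ethyl, an amine or a carboxylic acid on this carbon would give.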